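Oxazole in Place of Pyridine on a Fused Bicyclic Agonist

This account rests on a few compounds, and the source may have more. Where it says the series, first, only, none or still open, it means among the compounds named here.

Measured compounds:
compound 1, `Cc1c(OCC2=NCCN2)ccc(Cl)c1NS(C)(=O)=O`, 25 nM
compound 2, `Clc1ccc2c(c1-c1ccn[nH]1)CCC2c1ncc[nH]1`, 322 nM
compound 3, `c1ccc(-c2cccc3c2CCC3c2ncc[nH]2)nc1`, 1150 nM

The study measured three compounds in a functional assay on CHO cells for agonist activity at Alpha-1A adrenergic receptor (Homo sapiens), read by FLIPR and calcium flux; a lower number here means that less compound is needed, a higher number that more compound is needed for the effect. Compound 1 gives 25 nM, compound 2 gives 322 nM and compound 3 gives 1150 nM. Compound 3 therefore has the highest number of the three in this assay: the gap to compound 2, its nearest neighbour, already lies beyond the usual scatter, and the gap to compound 1 is wider still. No pair among these three differs in only one place, so no single-point comparison is available.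

Compound 4, `c1cc(-c2ncco2)c2c(c1)C(c1ncc[nH]1)CC2`, has not yet been measured. It differs from compound 3 in one place: 1,3-oxazol-2-yl in place of pyridin-2-yl on an aromatic carbon. The two groups sit on the same aromatic carbon of the fused system, and compound 4 carries the smaller five-membered ring there. Among the compounds with values here, with no related pair to draw on, the expectation is that the number stays close to that of compound 3, and the expected step of a 1.3-fold higher number from compound 3 to compound 4 (0.12 log units; within the scatter) is judged to be small, not clearly beyond the scatter. Compound 4 is accordingly expected to give about 1500 nM in this assay, within a range of 400 nM to 6000 nM.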

Compound 4, half-maximal effective concentration: 170 nM
Estimate against measurement, compound 4: 8.8-fold (0.95 log units) above; measured number outside the range, below it.
By their numbers in this assay, from the lowest: compound 1; then compounds 4 and 2 (each within the scatter of the next); then compound 3.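

In this assay, replacing pyridin-2-yl with 1,3-oxazol-2-yl on an aromatic carbon of the six-membered aromatic ring of carbon only gives a 6.8-fold lower number from compound 3 to compound 4 (0.83 log units; beyond the scatter). Within the data shown here, this is the first one-place comparison, and it shows that the number responds to which aromatic ring sits at this position, something the earlier compounds could not show. The change alters several things at once: a six-membered aromatic ring with 1 hetero atom gives way to a five-membered aromatic ring with 2 hetero atoms, oxygen enters, and the count of hydrogen-bond acceptors rises, so this single step cannot separate these differences, and nothing available bears on why the number moves.

Going by these compounds, it remains open whether other groups on this aromatic carbon, such as thiazol-2-yl, phenyl or a simple amine, would give a number closer to that of compound 4 or of compound 3. Among these compounds, it is also open whether the same exchange would produce a step of similar size on a different core, since this single pair is the only evidence for it.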